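A few compounds are considered here, and "the series" means these few. Any claim that something is new, unique, unknown or untested is made for them only; others in the source may bear on it.

Compound 1 `CCNC(=O)c1nc(-c2cc(OC)c(OC)c(OC)c2)n(-c2ccc(OC)cc2)n1` is the reference point of this pair of notes. For the measured compounds named here, in a functional assay on the whole organism for inhibition, with Rattus norvegicus as the target, read by paw edema, with stated times of 30 min and 5 h, at a dose of 0.28 mmol/kg by the oral route (on this read-out higher numbers stand for more inhibition at the one dose given (going by the name of the read-out) and lower numbers for less inhibition), compound 1 gives 52%, which is the highest of the two numbers measured so far; its nearest neighbour is compound 2 `COc1ccc(-n2nc(C(=O)Nc3ccc(C)cc3)nc2-c2cc(OC)c(OC)c(OC)c2)cc1`, which in this assay gives 42%. Going by the values given here, the one step measured between them, a number 10 percentage points lower from compound 1 to compound 2 (within the scatter), came with 4-methylphenyl in place of ethyl on an amide-type nitrogen, and it stays within the scatter of the read-out.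

Compound 3 `COc1ccc(-n2nc(C(=O)Nc3ccc(C(=O)O)cc3)nc2-c2cc(OC)c(OC)c(OC)c2)cc1` has not yet been measured. Relative to compound 1 the change is 4-carboxyphenyl in place of ethyl on an amide-type nitrogen. Among the compounds with values here, the only measured step that bears on it is the one from compound 1 to compound 2, since both replace the ethyl on the same amide-type nitrogen with a six-membered aromatic ring of carbon only; that step, a number 10 percentage points lower from compound 1 to compound 2 (within the scatter), was within the scatter. For compound 3 a step of comparable size and in the same direction, and so none beyond the scatter, is therefore expected, a number 10 percentage points lower from compound 1 to compound 3 (within the scatter). On that basis compound 3 is estimated to give 42% in this assay, within a range from 25% to 58%.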

Compound 3, a percentage reported as inhibition, in the whole organism at one dose (the size of the read-out at that dose, not a potency): 60%
Beside the measured number, compound 3's estimate is 18 percentage points below it; measured number above the stated range.
By their numbers in this assay, from the lowest: compounds 2, 1 and 3 (each within the scatter of the next, the first and the last beyond it).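

At the amide-type nitrogen, a large aromatic substituent carrying a carboxy group is accommodated in this assay: exchanging ethyl for 4-carboxyphenyl leaves the read-out within the scatter (a number 8 percentage points higher from compound 1 to compound 3 (within the scatter)). For the compounds shown here, the substituent on the aromatic ring matters more than the earlier pair could show, since carboxy in place of methyl on an aromatic carbon gives the only step in this set that lies beyond the scatter, though a modest one (a number 18 percentage points higher from compound 2 to compound 3 (beyond the scatter)). Nothing measured here accounts for that step.

The three compounds do not settle whether this step is specific to the carboxylic acid or would also appear with another group on that aromatic carbon, such as an amine, a hydroxy group or a methyl ester. As far as these compounds go, it also remains open whether a carboxylic acid needs the aromatic ring at all or would give a similar read-out on a short chain such as carboxymethyl on the same nitrogen, and each reading rests on a single dose.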